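From Amino to Fluoro on the Outer Phenyl Ring

The source may report more compounds than this note shows. Statements on the series, on what has been measured and on what is new or still open speak of the compounds shown alone.

Compound 1 `CNC(=O)c1cccc(-c2ccc(OC)c(S(=O)(=O)Nc3cccc(NCCNC(=O)c4ccccc4OC)c3)c2)c1`: 182 nM
Compound 2 `COc1ccccc1C(=O)NCCNc1cccc(NS(=O)(=O)c2cc(-c3cccc(N)c3)ccc2OC)c1`: > 1000 nM

In an assay on CHO-K1 cells for agonist activity at Orexin receptor type 2 (Homo sapiens), read by a luciferase reporter (on this read-out lower numbers stand for an effect already at smaller amounts and higher numbers for an effect only at larger amounts of compound), compound 1 gives 182 nM. Compound 2 sits at the limit of > 1000 nM in this assay, at which 1 of the 2 values shown sits, which is a limit of this assay and not a number. Among the compounds with values here, the single measured step, an at least 5.4-fold higher number from compound 1 to compound 2 (0.73 log units; beyond the scatter), is the only one touching this position, and it says nothing about fluoro. Compound 3 `COc1ccccc1C(=O)NCCNc1cccc(NS(=O)(=O)c2cc(-c3cccc(F)c3)ccc2OC)c1` differs from compound 2 by fluoro in place of amino on an aromatic carbon. With no guide for fluoro, only a small shift is expected, as a step that the limit leaves unreadable from compound 2 to compound 3. Compound 3 is therefore expected to give about 1200 nM, between 250 nM and 6000 nM, quite possibly again only a limit.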

Compound 3, half-maximal effective concentration: > 10000 nM
Compound 3 gave a limit, no number; the forecaster's own chance of this, stated with the estimate: 50%; at least 8.3-fold (0.92 log units) between middle value and limit.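

In this assay compound 3 reaches only a limit, > 10000 nM, and not a number. Swapping the methylcarbamoyl group for fluoro gives an at least 54-fold higher number from compound 1 to compound 3 (1.73 log units; beyond the scatter), and methylcarbamoyl remains the only group at this position with a measured number. The step from compound 2 to compound 3 cannot be read, and neither can any order between amino and fluoro.

Still open, going by these compounds, is which part of the methylcarbamoyl group matters. A primary amide, a nitrile or a carboxylic acid at this position could show whether a measured number like that of compound 1, 182 nM, survives.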